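The source may report more compounds than this note shows. Statements on the series, on what has been measured and on what is new or still open speak of the compounds shown alone.

Within the data shown here, in an ADME assay on HEK293 cells (Homo sapiens) for cytotoxicity, read by CellTiter-Glo and resazurin assay, with a stated time of 72 h (on this read-out lower numbers stand for an effect already at smaller amounts and higher numbers for an effect only at larger amounts of compound), the three compounds measured so far give no exact number. Compound 1 `CC(C)N(Cc1cccc(OCCCCCC(=O)O)c1)C(=O)c1ccc(-c2cccc(F)c2)cc1` reads > 26000 nM, which is a limit. Compound 2 `CCOC(=O)CCCCCOc1cccc(CN(C(=O)c2ccc(-c3cccc(NC(C)=O)c3)cc2)C(C)C)c1` reads > 26000 nM, also a limit. As far as these compounds go, compound 3 `CCOC(=O)CCCCCOc1cccc(CN(C(=O)c2ccc(-c3cccc(OCC)c3)cc2)C(C)C)c1` reads > 22300 nM, again a limit, so its true position is unknown. The values gather at two limits: the limit of > 26000 nM in this assay, at which 2 of the 3 values shown sit, and (the limit of > 22300 nM in this assay, at which 1 of the 3 values shown sits).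

Compound 4 `CCOC(=O)CCCCCOc1cccc(CN(C(=O)c2ccc(-c3cccc(F)c3)cc2)C(C)C)c1` differs from compound 3 in one place: fluoro in place of ethoxy on an aromatic carbon. Fluoro takes the place of ethoxy on an aromatic carbon, turning 3-ethoxyphenyl into 3-fluorophenyl. The closest measured change is a step that the two limits leave unreadable from compound 2 to compound 3, where ethoxy replaces acetamido on an aromatic carbon. It therefore gives no size to carry over. For compound 3, the limit of > 22300 nM is the only starting point, so another limit is the likely outcome in this assay.

The expected change is a step that the limit leaves unreadable from compound 3 to compound 4, with no shift in either direction beyond the scatter. For compound 4, the estimated value is 26000 nM, with an expected range from 14000 nM to 60000 nM.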

Compound 4, half-maximal effective concentration: > 26000 nM
Compound 4: only a limit was reported (the forecaster's own chance of this, stated with the estimate: 85%); the middle value sits exactly at the limit.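

In this assay, among these compounds, compound 4 gives only a limit, as do compound 1, compound 2 and compound 3, so no step between compound 4 and the others can be read. The compounds shown leave open where any true half-maximal concentration lies, and whether exchanging fluoro, ethoxy or acetamido changes it.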